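This account rests on a few compounds, and the source may have more. Where it says the series, first, only, none or still open, it means among the compounds named here.

Working notes on the series. Within the data shown here, compound 3 `CC1=C(C(=O)OC2CCC2)C(c2ccco2)NC(=O)N1` gives the lowest number of the three measured so far: in an assay on membranes from HEK293 cells for displacement of a labelled ligand from adenosine receptor A2b (Homo sapiens), read by scintillation counting, with a stated time of 30 min (a lower number here means a stronger inhibitor, a higher number a weaker inhibitor), compound 3 gives 95.1 nM. Compound 1 `CCCOC(=O)C1=C(C)NC(=O)NC1c1cccs1` gives 1520 nM in this assay, and compound 2 `CC1=C(C(=O)OCC(C)C)C(c2cccs2)NC(=O)N1` gives 2130 nM; both gaps to compound 3 lie beyond the scatter. Among the measured compounds shown here, the single measured one-place step, a 1.4-fold higher number from compound 1 to compound 2 (0.15 log units; within the scatter), concerns a saturated chain carbon and not the ring carbon altered here, so it does not bear on the present change. Compound 4 `CC1=C(C(=O)OC2CCC2)C(c2cccs2)NC(=O)N1` differs from compound 3 by thiophen-2-yl in place of furan-2-yl on a saturated ring carbon. For the measured compounds named here, compounds 1 and 2 also carry thiophen-2-yl, but with a different group of 7 heavy atoms, so their gaps to compound 3 combine two changes and no step isolates the heteroaryl swap. Because compound 1 at 1520 nM and compound 2 at 2130 nM both hold thiophen-2-yl and both give higher numbers, a moderately higher number is expected for compound 4, with wide uncertainty. For compound 4 the expected value in this assay is 150 nM, between 40 nM and 600 nM. The expected step is a 1.6-fold higher number from compound 3 to compound 4 (0.20 log units; within the scatter).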

Compound 4, inhibition constant: 1090 nM
For compound 4 the middle estimate is 7.3-fold (0.86 log units) below the measured one; the measured number lies above the stated range.
By their numbers in this assay, from the lowest: compound 3; then compounds 4, 1 and 2 (each within the scatter of the next).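

In this assay, with cyclobutyl held on the oxygen next to a carbonyl group, thiophen-2-yl in place of furan-2-yl on the saturated ring carbon gives an 11-fold higher number from compound 3 to compound 4 (1.06 log units; beyond the scatter) and so separates two groups that match in heavy-atom count, donors and acceptors. With thiophen-2-yl held, cyclobutyl in place of isobutyl gives a 2.0-fold lower number from compound 2 to compound 4 (0.29 log units; within the scatter) and cyclobutyl in place of propyl gives a 1.4-fold lower number from compound 1 to compound 4 (0.14 log units; within the scatter) so that compound 1, compound 2 and compound 4 cannot be told apart, and here the low number of compound 3 goes with furan-2-yl rather than with cyclobutyl alone. Nothing at hand speaks to what lies behind the large step.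

Furan-2-yl appears here only with cyclobutyl, so whether it gives a similar step with propyl or isobutyl remains open. Also open, from the compounds shown here alone, is how a phenyl ring or a pyridine ring would compare on the same saturated ring carbon.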